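Dropping the trifluoromethoxy group from compound 2

The source may report more compounds than this note shows. Statements on the series, on what has been measured and on what is new or still open speak of the compounds shown alone.

Three analogues sharing one core have been measured in a functional assay on 5637 cells (Homo sapiens) for cytotoxicity, read by resazurin assay, with a stated time of 72 h; a higher number here means a weaker inhibitor, a lower number a stronger inhibitor. Compound 1 `Cc1cc(OC(F)(F)F)ccc1/N=c1\ssnc1Cl` gives 47000 nM in this assay. Compound 2 `FC(F)(F)Oc1ccc(/N=c2\ssnc2Cl)cc1Br` gives 36000 nM in this assay. Compound 3 `CSc1ccc(/N=c2\ssnc2Cl)cc1` gives 34000 nM in this assay. On these numbers compound 2 stands with compound 3 as its nearest neighbour and compound 1 as its furthest, and both of those gaps fall within the usual scatter of repeated measurements, so no order among the three can be read with confidence.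

Compound 4 `Clc1nss/c1=N\c1cccc(Br)c1` has not yet been measured in this assay. It differs from compound 2 in one place: hydrogen in place of trifluoromethoxy on an aromatic carbon. The bromo group and the rest of the core are unchanged. For the measured compounds named here, no pair of measured compounds differs in exactly this way, so there is no directly comparable step to lean on; the only guide is that the three measured compounds, with differing substituents on the same ring, sit close together.

Compound 4 is therefore expected to stay near compound 2, with a step from compound 2 to compound 4 of a 1.3-fold higher number from compound 2 to compound 4 (0.10 log units; within the scatter), not clearly beyond the scatter. The estimate for compound 4 in this assay is 45000 nM, with a range from 15000 nM to 130000 nM.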

Compound 4, half-maximal inhibitory concentration: 53000 nM
Compound 4: the middle estimate sits 1.2-fold (0.07 log units) below what was measured, within the range that was stated.
By their numbers in this assay, from the lowest: compounds 3, 2, 1 and 4 (each within the scatter of the next).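

Working notes on the trifluoromethoxy position: this is the first change in one place in the series, on an aromatic carbon ortho to a bromo group and para to a group of 7 heavy atoms, and in this assay hydrogen in place of trifluoromethoxy reads as a 1.5-fold higher number from compound 2 to compound 4 (0.17 log units; within the scatter). The trifluoromethoxy group and its 5 heavy atoms can therefore leave this position with no difference that can be read in this assay, and compound 4 remains indistinguishable from compound 2 on these numbers. No measurement at hand offers an explanation for this result.

Whether any group at this position can move the number beyond the scatter remains open, as the compounds shown do not include an amine, a carboxylic acid or a longer chain there. The bromo group is open as well: no pair shown differs at that group alone, so its contribution in this assay cannot be read.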